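A few compounds are considered here, and "the series" means these few. Any claim that something is new, unique, unknown or untested is made for them only; others in the source may bear on it.

Of the compounds shown here, three from this series have been measured in a physicochemical assay for acid dissociation, and a fourth awaits measurement. Compound 1 `O=C1OC(C(O)CO)C(OCCCCCCO[N+](=O)[O-])=C1O` gives 7.6, the highest of the three numbers. Compound 2 `O=C1OC(C(O)CO)C(O)=C1OCCCCCCO[N+](=O)[O-]` gives 3.56, and compound 3 `O=C1OC(C(O)CO)C(O)=C1OCCCO[N+](=O)[O-]` gives 3.19. Compound 1 and compound 2 are built from the same atoms joined differently, so the difference between the two cores is not broken down here; the two values show that compound 1 sits far above compound 2.

From compound 2 to compound 3 the structural change is nitrooxy in place of 3-(nitrooxy)propyl on a saturated chain carbon, three bonds along the chain from an oxygen on an unsaturated carbon, and in this assay it gave a number 0.37 log units lower from compound 2 to compound 3 (beyond the scatter).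

Compound 4 `O=C1OC(C(O)CO)C(OCCCO[N+](=O)[O-])=C1O` is the unmeasured member. It differs from compound 1 by nitrooxy in place of 3-(nitrooxy)propyl on a saturated chain carbon, three bonds along the chain from an oxygen on an unsaturated carbon, which is the same change that was made from compound 2 to compound 3, in the same place. Because compound 2 to compound 3 gave a number 0.37 log units lower from compound 2 to compound 3 (beyond the scatter), the step from compound 1 to compound 4 in this assay is expected to be of a similar size and in the same direction, namely a number 0.40 log units lower from compound 1 to compound 4 (beyond the scatter). That expectation rests on a single measured instance of the change, made on a core whose relation to the core of compound 1 is not broken down, so it carries some uncertainty. Compound 4 is therefore estimated to give 7.2 in this assay, with a range from 6.8 to 7.7.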

Compound 4, acid dissociation constant: 7.55
Beside the measured number, compound 4's estimate is 0.35 log units below it; the measured number falls inside the stated range.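

In this assay the change of nitrooxy in place of 3-(nitrooxy)propyl gave a number 0.05 log units lower from compound 1 to compound 4 (within the scatter) on the core of compound 1, whereas the same change on the other core gave a number 0.37 log units lower from compound 2 to compound 3 (beyond the scatter) and so lay beyond the scatter. This shows that a step measured on one core did not carry over in size to the other in this series: the change registered on the core of compound 2 but left no step beyond the scatter on the core of compound 1. It does not show that the change never matters on the core of compound 1 or always matters on the core of compound 2, as each core offers a single pair, and nothing given here accounts for the different outcomes on the two cores.

The compounds shown leave open whether a longer chain would give a step beyond the scatter on the core of compound 1, or whether the step seen on the core of compound 2 would continue in the same direction. They also leave open how either core would read in this assay with an amine or a carboxylic acid in place of the nitrooxy group.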